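The source may hold more compounds than are shown below. What is called first, only, known or untested is meant among the compounds shown, and "the series" means these compounds.

In a functional assay on MCF7 cells (Homo sapiens) for inhibition, read by MTT assay, with a stated time of 48 h, tested at 10 uM (on this read-out higher numbers stand for more inhibition of growth at the one concentration tested and lower numbers for less inhibition of growth), compound 1 `COc1ccc(C(=O)/C=C/c2ccc(OCc3cn(Cc4ccccc4)nn3)cc2)cc1` gives 70%. Compound 2 `COc1ccc(C(=O)/C=C/c2ccc(OCc3cn(Cc4ccccc4Br)nn3)cc2)cc1` gives 60% in this assay, and compound 3 `COc1ccc(C(=O)/C=C/c2ccc(OCc3cn(Cc4ccccc4F)nn3)cc2)cc1` gives 32%. Going by the values given here, compound 3 thus stands lowest of the three numbers so far: the nearest, compound 2, lies higher by a step beyond the scatter, and compound 1 lies further away still. The steps leading to compound 3 are a number 38 percentage points lower from compound 1 to compound 3 (beyond the scatter) and a number 28 percentage points lower from compound 2 to compound 3 (beyond the scatter), whereas a number 10 percentage points lower from compound 1 to compound 2 (within the scatter).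

Compound 4 `COc1ccc(C(=O)/C=C/c2ccc(OCc3cn(Cc4ccc(F)cc4)nn3)cc2)cc1` remains to be measured. Relative to compound 3 it carries 4-fluorophenyl in place of 2-fluorophenyl on a saturated chain carbon bound to an aromatic nitrogen. Among the compounds with values here, no measured pair shows the fluorine moved from one place on that ring to another; the measured steps only exchange the group at a single place. Fluoro in place of hydrogen there gave the large drop a number 38 percentage points lower from compound 1 to compound 3 (beyond the scatter), while compound 2 with bromo lies within the scatter of compound 1. Whether the drop follows the fluorine to its new place is open, so the expectation sits between the two outcomes: compound 4 is expected to show a step of a number 18 percentage points higher from compound 3 to compound 4 (beyond the scatter) in this assay, with wide uncertainty. The estimate for compound 4 in this assay is 50%, within a range from 30% to 70%.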

Compound 4, percent growth inhibition at one concentration: 15%
Beside the measured number, compound 4's estimate is 35 percentage points above it; the measured number lies below the stated range.
By their numbers in this assay, from the lowest: compound 4; then compound 3; then compounds 2 and 1 (each within the scatter of the next).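

Notes on the benzyl group on the triazole side of the series: in this assay, exchanging 2-fluorophenyl for 4-fluorophenyl keeps the same atoms yet gives a number 17 percentage points lower from compound 3 to compound 4 (beyond the scatter), so the place of the fluorine on this ring matters as well as its presence. The low number does not depend on one fluorine place: fluoro lowers the number at both places shown, and the 4-fluorophenyl group gives a number 55 percentage points lower from compound 1 to compound 4 (beyond the scatter) against the unsubstituted phenyl group. Against the 2-bromophenyl group it gives a number 45 percentage points lower from compound 2 to compound 4 (beyond the scatter), although that step changes both the halogen and its place, and nothing shown explains why the two fluorine places differ.

As far as these compounds go, whether bromo follows the same course when it stands where the fluorine stands in the 4-fluorophenyl group remains open, so halogen and place cannot yet be separated for bromo. Also open, from the compounds shown here alone, is how an amine or a carboxylic acid on this ring would read out in place of the halogens, since only hydrogen, fluoro and bromo are covered here.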